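Estimating a Chlorotriazine Swap on Compound 2

The compounds below may be only part of what the source reports. "The series", "measured", "known", "first", "only" and "open" are said of these compounds alone.

Measured in a toxicity assay on KB cells (Homo sapiens) for cytotoxicity, read by fluorescence, with a stated time of 3 days; on this read-out lower numbers stand for an effect already at smaller amounts and higher numbers for an effect only at larger amounts of compound:
- Compound 1 `CCCCOC(=O)CNC(=O)[C@H](CSc1ccc([N+](=O)[O-])cc1[N+](=O)[O-])NC(=O)CC[C@H](NC(=O)c1ccccc1)C(=O)OCCCC`: > 300 uM, a limit
- Compound 2 `CCCCOC(=O)CNC(=O)[C@H](CSc1ccc([N+](=O)[O-])cc1[N+](=O)[O-])NC(=O)CC[C@H](NC(=O)CCC(C)C)C(=O)OCCCC`: 84 uM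
- Compound 3 `CCCCOC(=O)CNC(=O)[C@H](CSc1ccc([N+](=O)[O-])cc1[N+](=O)[O-])NC(=O)CC[C@H](NC(=O)CC(C)(C)C)C(=O)OCCCC`: 250 uM

Of the two actual numbers, the lower belongs to compound 2, and the value for compound 1 is only a limit. Compound 4 `CCCCOC(=O)CNC(=O)[C@H](CSc1ccc([N+](=O)[O-])cc1[N+](=O)[O-])NC(=O)CC[C@H](Nc1nc(N)nc(Cl)n1)C(=O)OCCCC` is not yet measured. It carries 4-amino-6-chloro-1,3,5-triazin-2-yl in place of isopentylcarbonyl on an amine nitrogen. Within the data shown here, two measured steps bear on this: an at least 3.5-fold lower number from compound 1 to compound 2 (0.55 log units; beyond the scatter) and a 3.0-fold higher number from compound 2 to compound 3 (0.47 log units; beyond the scatter). In both, compound 2 holds the lower number, yet neither introduces a triazine, so they guide only loosely. A modest move to a higher number is therefore expected in this assay, a 2.4-fold higher number from compound 2 to compound 4 (0.38 log units; beyond the scatter). The estimate for compound 4 is 200 uM, with an expected range of 50 uM to 500 uM.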

Compound 4, concentration for half-maximal effect: > 300 uM
Compound 4: a limit, no number (the forecaster's own chance of this, stated with the estimate: 25%); middle value at least 1.5-fold (0.17 log units) from the limit.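

Putting a ring on this amine nitrogen, with 4-amino-6-chloro-1,3,5-triazin-2-yl replacing isopentylcarbonyl, gives an at least 3.5-fold higher number from compound 2 to compound 4 (0.55 log units; beyond the scatter) in this assay, so this triazine does not keep the lower number of compound 2. Against neopentylcarbonyl, the same kind of swap gives an at least 1.2-fold higher number from compound 3 to compound 4 (0.07 log units; that floor lies within the scatter), so no real difference from compound 3 can be claimed. Compound 4 gives > 300 uM, which is a limit, and its step from compound 1 cannot be read: the limit of > 300 uM in this assay, at which 2 of the 4 values shown sit.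

Going by these compounds, whether the chlorine or the ring itself drives the step from compound 2 stays open. A triazine carrying a second amine in place of the chlorine, or a plain pyridine ring on this nitrogen, could separate the two.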